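Fluoro substitution on a pendant phenyl, read-through to compound 4

A few compounds are considered here, and "the series" means these few. Any claim that something is new, unique, unknown or untested is made for them only; others in the source may bear on it.

Compound 1 `COc1ccc(-c2cc(C(C)=O)c3[nH]c(-c4ccccc4)cc3c2)cc1` gives 33.9% in a functional assay on HeLa cells (Homo sapiens) for cytotoxicity, read by MTT assay, with a stated time of 2 days, tested at 10 uM; a lower number here means a stronger effect, a higher number a weaker effect of the compound at the concentration tested. Compound 2 `COc1ccc(-c2cc(C(C)=O)c3[nH]c(-c4ccc(F)cc4)cc3c2)cc1` gives 46.5% in this assay, the change being fluoro in place of hydrogen on an aromatic carbon and the step of a number 12.6 percentage points higher from compound 1 to compound 2 (beyond the scatter). Compound 3 `CC(=O)c1cc(/C=C/c2ccccc2)cc2cc(-c3ccc(F)cc3)[nH]c12` gives 51.9%; the step of a number 5.4 percentage points higher from compound 2 to compound 3 (within the scatter) is within the scatter. The difference between the core of compound 1 and the core of compound 3 is not broken down here. Compound 4 `CC(=O)c1cc(/C=C/c2ccc(F)cc2)cc2cc(-c3ccc(F)cc3)[nH]c12` is not yet measured; it differs from compound 3 by fluoro in place of hydrogen on an aromatic carbon, the same change as from compound 1 to compound 2, at the same kind of place, here read one bond further out as 2-phenylethenyl to 2-(4-fluorophenyl)ethenyl. Among the compounds with values here, a step of about a number 10.1 percentage points higher from compound 3 to compound 4 (beyond the scatter) is expected, resting on the single precedent a number 12.6 percentage points higher from compound 1 to compound 2 (beyond the scatter). Compound 4 is expected to give 62%, between 50% and 74%.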

Compound 4, a percentage reported as activity, at one concentration (the size of the read-out at that concentration, not a potency): 41.9%
Beside the measured number, compound 4's estimate is 20.1 percentage points above it, outside the stated range (below it).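

In this assay, fluoro in place of hydrogen does not carry from one core to the other as a fixed step: the same change on two cores in this assay, a number 12.6 percentage points higher (beyond the scatter) from compound 1 to compound 2 and a number 10 percentage points lower (within the scatter) from compound 3 to compound 4, 22.6 percentage points apart, beyond the scatter of two such steps. Read alone, the new result is a number 10 percentage points lower from compound 3 to compound 4 (within the scatter), and the comparison with the 4-methoxyphenyl compound is a number 4.6 percentage points lower from compound 2 to compound 4 (within the scatter), so neither step separates the compounds it joins. With a single pair on each core, this shows that the step is not transferable between these two cores, but not why the two steps part or how the change would read on a further core.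

Still open, from the compounds shown here alone, is how a chloro group, an amine or a carboxylic acid in place of the fluoro would read in this assay.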